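The source may hold more compounds than are shown below. What is called first, only, known or untested is meant among the compounds shown, and "the series" means these compounds.

Working notes on the series. Compound 1 `c1ccc2c(c1)COC(c1c[nH]c3ccccc13)N2` gives 11500 nM in an assay on isolated protein for inhibition of Alpha glucosidase (Homo sapiens); on this read-out higher numbers stand for weaker inhibition and lower numbers for stronger inhibition. Compound 2 `Clc1ccc2c(c1)COC(c1c(-c3ccccc3)[nH]c3ccccc13)N2`, which carries a chloro and a phenyl group, gives 11500 nM in this assay, level with compound 1 at the digits shown, within the scatter. Compound 3 `Cc1ccc2c(c1)COC(c1c(-c3ccccc3)[nH]c3ccccc13)N2` is the next member, with methyl in place of chloro on an aromatic carbon. Since compound 1 and compound 2 sit at the same level, an exchange of one small group for another on the same aromatic carbon is expected to give no step beyond the scatter, the expected step being no change at the digits printed from compound 2 to compound 3 (within the scatter). Compound 3 is therefore estimated at 11500 nM, with a range from 5000 nM to 26000 nM.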

Compound 3, half-maximal inhibitory concentration: 11500 nM
Compound 3: the middle estimate sits on the measured number at the digits printed; the range from low to high includes it.
By their numbers in this assay, from the lowest: compounds 1, 2 and 3 (each within the scatter of the next).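

Among the compounds shown here, with methyl in place of chloro on an aromatic carbon, this assay gives no change at the digits printed from compound 2 to compound 3 (within the scatter), the first step that can be read for a change in one place. At this position, the two small groups, each of one heavy atom, therefore read alike on this assay. Nothing available gives a reason for this result.

Going by these compounds, whether an amine or a carboxylic acid on the same aromatic carbon would also read alike remains open. On these data alone, the separate contribution of the phenyl group also remains open.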